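A Ring Swap on a Weak Thyroid Receptor Scaffold

A few compounds are considered here, and "the series" means these few. Any claim that something is new, unique, unknown or untested is made for them only; others in the source may bear on it.

Of the compounds shown here, three that share one core have been tested in an assay on isolated protein for inhibition of thyroid hormone receptor beta (Homo sapiens), read by fluorescence polarization; a higher number here means a weaker inhibitor, a lower number a stronger inhibitor. Compound 1 `CS(=O)(=O)c1ccc(C(=O)N2CCC(C(=O)N3CCN(c4ccc(F)cc4)CC3)CC2)cc1[N+](=O)[O-]` reaches only the limit of the assay, giving > 60000 nM. Among the measured compounds shown here, compound 3 `CN(Cc1ccccc1)C(=O)CNC(=O)c1ccc(S(C)(=O)=O)c([N+](=O)[O-])c1` is the one compound that gives a number, 39000 nM. Compound 2 `CS(=O)(=O)c1ccc(C(=O)NCCC(=O)N2CCc3ccccc32)cc1[N+](=O)[O-]` likewise stops at the limit, giving > 60000 nM. Compound 2 therefore stands at the boundary of what the assay can read, and it shares that boundary with one other compound, as the limit of > 60000 nM in this assay, at which 2 of the 3 values shown sit, shows.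

Compound 4 `CS(=O)(=O)c1ccc(C(=O)NCCC(=O)N2CCc3ccccc3C2)cc1[N+](=O)[O-]` has not yet been measured. It differs from compound 2 in a single place: 1,2,3,4-tetrahydroisoquinolin-2-yl in place of 2,3-dihydro-1H-indol-1-yl on a carbonyl carbon. One nitrogen-containing ring fused to a benzene ring is thus exchanged for another of a different size, on the same carbonyl carbon.

For the measured compounds named here, no pair of measured compounds differs in only one place, so no measured step is available to guide the expectation. With compound 2 at the limit, the step from compound 2 to compound 4 is expected to be a number no higher from compound 2 to compound 4 (the limit leaves the size open) in this assay, that is, no change beyond the scatter. Compound 4 is expected to give about 60000 nM, within a range from 20000 nM to 200000 nM, and most likely to return only a limit once more.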

Compound 4, half-maximal inhibitory concentration: > 60000 nM
Compound 4 gave a limit, no number (the forecaster's own chance of this, stated with the estimate: 75%); the middle value lies on the limit itself.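

In this assay compound 4 gives > 60000 nM, which is a limit and not a number. Compound 2 also stands at a limit, so the step from compound 2 to compound 4 cannot be read: the limit of > 60000 nM in this assay, at which 3 of the 4 values shown sit. The compounds shown leave open whether 1,2,3,4-tetrahydroisoquinolin-2-yl and 2,3-dihydro-1H-indol-1-yl differ at all in this assay.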